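Hydrogen in place of methoxy on compound 2

The source may hold more compounds than are shown below. What is called first, only, known or untested is meant among the compounds shown, and "the series" means these compounds.

Only limits are available so far in a functional assay on HL-60 cells (Homo sapiens) for antiproliferative activity (a higher number here means a weaker inhibitor, a lower number a stronger inhibitor), for this series. Compound 1 `Oc1cccc2nccc(O)c12` reads > 30000 nM as a limit and gives no number. Compound 2 `COc1cc2nccc(O)c2c(O)c1OC` reads > 30000 nM as a limit and gives no number either. Compound 3 `COc1cc2nccc(O)c2c(OC)c1OC` reads > 30000 nM as a limit as well. Within the data shown here, compound 2 therefore has no numerical position, and the series so far shows the limit of > 30000 nM in this assay, at which 3 of the 3 values shown sit, with nothing measured inside the range.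

Compound 4 `COc1cc(O)c2c(O)ccnc2c1` differs from compound 2 by hydrogen in place of methoxy on an aromatic carbon and carries hydrogen in place of methoxy on an aromatic carbon. Among the measured compounds shown here, the one measured step nearby is a step that the two limits leave unreadable from compound 2 to compound 3 and it offers no size to carry over. Compound 1 and compound 2 both stand at limits, so that pair offers no size either. For the measured compounds named here, with the limit of > 30000 nM in this assay, at which 3 of the 3 values shown sit, as the only guide, no step beyond the scatter is expected in this assay for this change, and a further limit is the likeliest report. The expected size is a number no higher from compound 2 to compound 4 (the limit leaves the size open) as estimated here. For compound 4 the estimated value is 30000 nM within an expected range of 15000 nM to 60000 nM in this series.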

Compound 4, half-maximal inhibitory concentration: > 30000 nM
Compound 4 ended at the assay's limit; the forecaster's own chance of this, stated with the estimate: 85%; the middle value lies on the limit itself.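

Neither step to compound 4, from compound 1 or from compound 2, can be read in this assay, since all three compounds stand at a limit: the limit of > 30000 nM in this assay, at which 4 of the 4 values shown sit.

The compounds shown leave open whether any change on the shared core brings a measurable value in this assay.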